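A few compounds are considered here, and "the series" means these few. Any claim that something is new, unique, unknown or untested is made for them only; others in the source may bear on it.

Measured compounds:
compound 1 `CC(C)C[C@@H](c1nc2ccc(C(=O)O)cc2n1C)N1C(=O)CN(c2ccc(F)cc2)C1=O` — 399000 nM
compound 2 `CC(C)C[C@@H](c1nc2ccc(C(=O)O)cc2n1C)N1C(=O)CN(c2ccc(OC3CCCCC3)cc2)C1=O` — 126000 nM

Both compounds were tested in an assay on isolated protein for inhibition of Bile acid receptor (Homo sapiens), read by TR-FRET and LanthaScreen; a higher number here means a weaker inhibitor, a lower number a stronger inhibitor. Compound 1 gives 399000 nM, and compound 2 gives 126000 nM, which is the lowest of the two numbers at hand. Among the compounds with values here, the only step measured so far, a 3.2-fold lower number from compound 1 to compound 2 (0.50 log units; beyond the scatter), puts compound 2 a modest distance below compound 1.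

Compound 3 `CC(C)C[C@@H](c1nc2ccc(C(=O)O)cc2n1C)N1C(=O)CN(c2ccc(Oc3ccc(Cl)cc3)cc2)C1=O` is the next compound in the series and has not yet been measured in this assay. Its structure differs from compound 2 in one place: 4-chlorophenyl in place of cyclohexyl on an oxygen on an aromatic ring. Within the data shown here, no measured step touches this position in the same way, since the one step that exists, a 3.2-fold lower number from compound 1 to compound 2 (0.50 log units; beyond the scatter), concerns a different exchange on that aromatic carbon. The data therefore give no direct guide, and a change no larger than the scatter is expected, with the number expected to stay near that of compound 2, 126000 nM. Compound 3 is estimated at 100000 nM, within 40000 nM to 300000 nM. This estimate corresponds to an expected step of a 1.3-fold lower number from compound 2 to compound 3 (0.10 log units; within the scatter).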

Compound 3, half-maximal inhibitory concentration: 2560 nM
For compound 3 the middle estimate is 39-fold (1.59 log units) above the measured one; measured number below the stated range.
By their numbers in this assay, from the lowest: compound 3; then compound 2; then compound 1.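

In this assay, within the data shown here, the group on the ether oxygen matters far more than the earlier pair could show: 4-chlorophenyl in place of cyclohexyl gives a 49-fold lower number from compound 2 to compound 3 (1.69 log units; beyond the scatter) and so outweighs the exchange of fluoro for cyclohexyloxy, which gave a 3.2-fold lower number from compound 1 to compound 2 (0.50 log units; beyond the scatter) in the only step previously available. Measured against fluoro, 4-chlorophenoxy gives a 160-fold lower number from compound 1 to compound 3 (2.19 log units; beyond the scatter) at the same aromatic carbon, and compound 2 and compound 3 stand far apart although both carry an oxygen there, so the oxygen link alone does not set the size of the step. No available measurement accounts for the difference between the cyclohexyl and 4-chlorophenyl groups.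

The compounds shown do not separate the contribution of the chlorine from that of the aromatic ring: that question would need an unsubstituted phenyl on the same oxygen, or a 4-methoxyphenyl or 4-methylphenyl. Also open, on these data alone, is whether the oxygen itself can be exchanged while 4-chlorophenyl stays in place, for example for a methylene or an amine nitrogen.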